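Nucleobase swap on the amino lactone: compound 2 to compound 3

The source may report more compounds than this note shows. Statements on the series, on what has been measured and on what is new or still open speak of the compounds shown alone.

Compound 1 `Nc1ncn(C/C=C2\OC(=O)C(OCc3ccccc3)=C2OCc2ccccc2)c(=O)n1` is measured in a functional assay on MCF7 cells (Homo sapiens) for inhibition, read by MTT assay, with a stated time of 72 h (a lower number here means a stronger inhibitor, a higher number a weaker inhibitor), at 3490 nM. Compound 2 `NC1(CCn2ncc(=O)[nH]c2=O)OC(=O)C(OCc2ccccc2)=C1OCc1ccccc1` gives only a limit of the assay in this assay, > 100000 nM. Compound 2 thus stands at the limit of > 100000 nM in this assay, at which 1 of the 2 values shown sits, and no number places it within the series. Compound 3 `Cc1cn(CCC2(N)OC(=O)C(OCc3ccccc3)=C2OCc2ccccc2)c(=O)[nH]c1=O` differs from compound 2 by a group of 9 heavy atoms (5 carbon, 2 nitrogen, 2 oxygen; one six-membered aromatic ring with 2 hetero atoms) in place of a group of 8 heavy atoms (3 carbon, 3 nitrogen, 2 oxygen; one six-membered aromatic ring with 3 hetero atoms), on a saturated chain carbon, two bonds along the chain from a saturated ring carbon. For the measured compounds named here, no measured step covers this change, so its size and direction are open; given that compound 2 itself shows > 100000 nM, the expected step of an at least 1.6-fold lower number from compound 2 to compound 3 (0.22 log units; that floor lies within the scatter) is estimated as small and unresolved. For compound 3 the expected value in this assay is 60000 nM, within 8000 nM to 200000 nM, with a real chance the assay again returns only a limit.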

Compound 3, half-maximal inhibitory concentration: 80400 nM
Beside the measured number, compound 3's estimate is 1.3-fold (0.13 log units) below it; the range from low to high includes it.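

With the group of 9 heavy atoms on the saturated chain carbon, the amino lactone gives a measurable number, and the change reads as an at least 1.2-fold lower number from compound 2 to compound 3 (0.09 log units; that floor lies within the scatter) in this assay. This is only a floor, so the true size of the step stays unresolved. The value of compound 2 is a limit of the assay, not a number: (the limit of > 100000 nM in this assay, at which 1 of the 3 values shown sits). As far as these compounds go, whether a larger step is hidden behind that limit remains open. Also open, from the compounds shown here alone, is how a purine such as adenine, or a longer chain carrying the same ring, would read at this place.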